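The source may hold more compounds than are shown below. What is called first, only, known or untested is meant among the compounds shown, and "the series" means these compounds.

Measured compounds:
compound 1 `Fc1ccc(-c2cc3c(cn2)ncn3-c2ccc(OC(F)F)cc2)c(Cl)c1` gives 90 nM
compound 2 `Fc1ccc(-c2cc3c(cn2)ncn3-c2ccc(OC(F)F)cc2)c(C(F)(F)F)c1` gives 1500 nM
compound 3 `CCCOc1cc(F)ccc1-c1cc2c(cn1)ncn2-c1ccc(OC(F)F)cc1` gives 58 nM

The three share one core and differ in a single group on an aromatic ring. In a functional assay on HL-60 cells (Homo sapiens) for activation, read by flow cytometry, with a stated time of 4 days (on this read-out lower numbers stand for an effect already at smaller amounts and higher numbers for an effect only at larger amounts of compound), compound 3 has the lowest number of the three, though its gap to compound 1 is small, a 1.6-fold lower number from compound 1 to compound 3 (0.19 log units; within the scatter), and only compound 2 stands clearly apart, a 26-fold lower number from compound 2 to compound 3 (1.41 log units; beyond the scatter). Compound 4 `CC(C)Oc1cc(F)ccc1-c1cc2c(cn1)ncn2-c1ccc(OC(F)F)cc1` differs from compound 3 in one place: isopropyl in place of propyl on an oxygen on an aromatic ring. Among the compounds with values here, none of the measured steps concerns such a change; each swapped one kind of group for another, whereas here the two compounds have the same atoms, joined differently. No step beyond the scatter is therefore expected in this assay. Compound 4 is expected to give 60 nM, between 25 nM and 150 nM. The expected step of a 1.0-fold higher number from compound 3 to compound 4 (0.01 log units; within the scatter) is estimated to stay within the usual scatter.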

Compound 4, half-maximal effective concentration: 1100 nM
Compound 4: middle estimate off by 18-fold (1.26 log units), on the low side; the measured number lies above the stated range.
By their numbers in this assay, from the lowest: compounds 3 and 1 (each within the scatter of the next); then compounds 4 and 2 (each within the scatter of the next).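

At this oxygen on an aromatic ring, how the same atoms are joined matters in this assay: isopropyl in place of propyl gives a 19-fold higher number from compound 3 to compound 4 (1.28 log units; beyond the scatter). The earlier steps shown here left propoxy and chloro within the scatter of each other, whereas isopropoxy stands clearly apart from chloro, a 12-fold higher number from compound 1 to compound 4 (1.09 log units; beyond the scatter), and cannot be separated from trifluoromethyl, a 1.4-fold lower number from compound 2 to compound 4 (0.13 log units; within the scatter). Nothing available here accounts for this change. On these data alone, whether an ethoxy, butoxy or cyclopropylmethoxy group would track propoxy or isopropoxy stays open.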